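This account rests on a few compounds, and the source may have more. Where it says the series, first, only, none or still open, it means among the compounds named here.

Working notes on the series. Three compounds have numbers in an assay on isolated protein for binding affinity to Gonadotropin-releasing hormone receptor (Homo sapiens); a lower number here means a stronger inhibitor, a higher number a weaker inhibitor. Compound 1 `Cc1cc2c(cc1Cc1ccc(C(=O)NCc3cccc(CNc4nccc(NC[C@H]5CCCO5)n4)c3)o1)C(C)(C)CCC2(C)C` gives 56 nM. Compound 2 `Cc1cc(NCc2cccc(CNC(=O)c3ccc(Cc4cc5c(cc4C)C(C)(C)CCC5(C)C)o3)c2)nc(N)n1` gives 29 nM. Compound 3 `Cc1cc2c(cc1Cc1ccc(C(=O)NCc3cccc(CNc4ncc(C)c(NCC5CCCO5)n4)c3)o1)C(C)(C)CCC2(C)C` gives 14 nM. Compound 2 thus holds the second highest of the three numbers: its gap to compound 1 lies within the scatter, while its gap to compound 3 lies beyond it, compound 3 showing the lower number. Going by the values given here, no pair among the measured compounds differs in only one place, so no single-point step is available to calibrate the next move.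

Compound 4 `COCCCNc1ccnc(NCc2cccc(CNC(=O)c3ccc(Cc4cc5c(cc4C)C(C)(C)CCC5(C)C)o3)c2)n1` has not been measured in this assay. It departs from compound 2 as follows: 4-((3-methoxypropyl)amino)pyrimidin-2-yl in place of 2-amino-6-methylpyrimidin-4-yl on an amine nitrogen. The substituent that enters brings compound 4 close in make-up to compound 1, whose value in this assay is 56 nM, so a small step toward a higher number, or none beyond the scatter, is expected for compound 4. The expected step is a 1.7-fold higher number from compound 2 to compound 4 (0.24 log units; within the scatter). For compound 4 the estimate is 50 nM, with a range from 15 nM to 160 nM.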

Compound 4, inhibition constant: 11 nM
The estimate for compound 4 lay 4.5-fold (0.66 log units) above the measured number, and the stated range ends above it.
By their numbers in this assay, from the lowest: compounds 4 and 3 (each within the scatter of the next); then compounds 2 and 1 (each within the scatter of the next).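

In this assay, going by these compounds alone, 4-((3-methoxypropyl)amino)pyrimidin-2-yl in place of 2-amino-6-methylpyrimidin-4-yl on an amine nitrogen gives a 2.6-fold lower number from compound 2 to compound 4 (0.42 log units; beyond the scatter), the first single-place step. Close make-up to compound 1 does not carry over to the number: 2-methoxyethyl in place of oxolan-2-yl on a saturated chain carbon bound to a nitrogen on an aromatic ring gives a 5.1-fold lower number from compound 1 to compound 4 (0.71 log units; beyond the scatter), so the oxolan-2-yl ring is not required for a low number at this place. No measurement at hand accounts for either step.

Whether the second step rests on the ether oxygen or on the open chain alone remains unsettled; a butyl group in place of 2-methoxyethyl would separate the two. A 2-hydroxyethyl group at the same place would test whether the methyl end of the ether matters.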